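Removing the Ring Chlorine from Compound 1

The source may report more compounds than this note shows. Statements on the series, on what has been measured and on what is new or still open speak of the compounds shown alone.

In a functional assay on LM7 cells (Homo sapiens) for antiproliferative activity, read by MTT assay, with a stated time of 72 h (a higher number here means a weaker inhibitor, a lower number a stronger inhibitor), compound 1 `O=c1c(CSC(=S)N2CCOCC2)coc2cc(Cl)ccc12` gives 6200 nM. Among the three numbers measured it stands second highest: compound 2 `O=c1c(CSC(=S)N2CCCCC2)coc2cc(Cl)ccc12` gives 850 nM, while compound 3 `O=c1c(Cl)c(CSC(=S)N2CCOCC2)oc2ccccc12` gives 19200 nM. Among the measured compounds shown here, the only single-change step on record, a 7.3-fold lower number from compound 1 to compound 2 (0.86 log units; beyond the scatter), concerns the amine attached to the thiocarbonyl carbon and says nothing about the aromatic ring. Compound 4 `O=c1c(CSC(=S)N2CCOCC2)coc2ccccc12` differs from compound 1 by hydrogen in place of chloro on an aromatic carbon. For the measured compounds named here, no measured step tests this change directly; compound 3 differs from compound 1 in two places at once, so its number cannot be attributed to the chloro alone. Without a guide, only a small shift in this assay is expected, if any beyond the scatter. For compound 4 the estimate is 8000 nM, between 3000 nM and 25000 nM, a step of a 1.3-fold higher number from compound 1 to compound 4 (0.11 log units; within the scatter).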

Compound 4, half-maximal inhibitory concentration: 12000 nM
Compound 4: middle estimate off by 1.5-fold (0.18 log units), on the low side; measured number inside the range.
By their numbers in this assay, from the lowest: compound 2; then compounds 1, 4 and 3 (each within the scatter of the next, the first and the last beyond it).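

In this assay the swap of chloro for hydrogen on this aromatic carbon gives a 1.9-fold higher number from compound 1 to compound 4 (0.29 log units; within the scatter) and so, with the morpholin-4-yl group in place, the chloro is not shown to matter here. Among the compounds shown here, this is the first direct reading of this position, free of the second difference that clouds compound 3. No supporting data bear on what lies behind this result. From the compounds shown here alone, whether the same swap would read alike with the piperidin-1-yl group of compound 2 stays open. So does the effect of a methoxy group or a bromine atom on this carbon.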